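Amide side chain: 2-carboxyethyl to 1,3-dicarboxypropyl

A few compounds are considered here, and "the series" means these few. Any claim that something is new, unique, unknown or untested is made for them only; others in the source may bear on it.

In a functional assay on PC-3 cells (Homo sapiens) for antiproliferative activity, read by MTT assay, with a stated time of 24 h (on this read-out lower numbers stand for stronger inhibition and higher numbers for weaker inhibition), compound 1 `CCn1c(C(=O)NCCO)ccc1C(CC)(CC)c1ccc(OCS(=O)(=O)c2ccccc2)c(C)c1` gives 17700 nM and compound 2 `CCn1c(C(=O)NCCC(=O)O)ccc1C(CC)(CC)c1ccc(OCS(=O)(=O)c2ccccc2)c(C)c1` gives 14400 nM. These two values lie within the scatter of each other, so compound 2 stands level with compound 1.

Compound 3 `CCn1c(C(=O)N[C@H](CCC(=O)O)C(=O)O)ccc1C(CC)(CC)c1ccc(OCS(=O)(=O)c2ccccc2)c(C)c1` carries 1,3-dicarboxypropyl in place of 2-carboxyethyl on an amide-type nitrogen.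

Going by the values given here, only one measured step bears on this change: a 1.2-fold lower number from compound 1 to compound 2 (0.09 log units; within the scatter), with carboxy in place of hydroxy on the chain carried by the same amide-type nitrogen. That step stays within the scatter. Among the compounds with values here, no measured compound carries 1,3-dicarboxypropyl, so the data give no direction for the new change. No step beyond the scatter is expected in this assay. The expected step is a 1.3-fold higher number from compound 2 to compound 3 (0.10 log units; within the scatter). For compound 3 the estimate is 18000 nM, with an expected range from 8000 nM to 40000 nM.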

Compound 3, half-maximal inhibitory concentration: > 50000 nM
Compound 3 was reported as a limit (the forecaster's own chance of this, stated with the estimate: 10%); at least 2.7-fold (0.44 log units) between middle value and limit.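

In this assay, going by these compounds alone, exchanging the groups on the amide-type nitrogen had so far produced no step beyond the scatter, but 1,3-dicarboxypropyl does so, with weaker inhibition against both earlier compounds: an at least 3.4-fold higher number from compound 2 to compound 3 (0.54 log units; beyond the scatter), and an at least 2.8-fold higher number from compound 1 to compound 3 (0.45 log units; beyond the scatter). The position is therefore not indifferent to every change in this side chain, even though 2-hydroxyethyl and 2-carboxyethyl stand level. The value of compound 3 is a limit and not a number: the limit of > 50000 nM in this assay, at which 1 of the 3 values shown sits.

1,3-Dicarboxypropyl brings in a second carboxy group, more heavy atoms and a defined stereocentre in one change, and the compounds shown do not separate these. Also open, on these data alone, is how the read-out would respond to a single carboxylic acid on a longer chain, or to an amine in place of the second carboxy group.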